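A few compounds are considered here, and "the series" means these few. Any claim that something is new, unique, unknown or untested is made for them only; others in the source may bear on it.

Compounds measured in a functional assay on MCF7 cells (Homo sapiens) for inhibition (on this read-out higher numbers stand for weaker inhibition and lower numbers for stronger inhibition), so far:
- compound 1, `CC/C(=C(/c1ccc(/C=C/C(=O)O)cc1)c1cc2ccccc2[nH]1)c1ccc(C(F)(F)F)cc1`: 139 nM
- compound 2, `CC/C(=C(/c1ccc(/C=C/C(=O)O)cc1)c1cc2ccccc2[nH]1)c1ccc(Cl)cc1Cl`: 11 nM
- compound 3, `CC/C(=C(/c1ccc(/C=C/C(=O)O)cc1)c1cc2ccccc2[nH]1)c1ccc(C#N)cc1Cl`: 49 nM

Compound 3 stands second highest of the three numbers in this assay. Its nearest neighbour is compound 1, which gives a higher number, while compound 2 gives the lowest number of the set.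

The next compound, compound 4, `CC/C(=C(/c1ccc(/C=C/C(=O)O)cc1)c1cc2ccccc2[nH]1)c1ccc(C(F)(F)F)cc1Cl`, differs from compound 3 in one place: trifluoromethyl in place of cyano on an aromatic carbon. For the measured compounds named here, no measured step shows this exact exchange. Going by the values given here, three steps bear on it indirectly. The step of a 13-fold lower number from compound 1 to compound 2 (1.10 log units; beyond the scatter) and the step of a 2.8-fold lower number from compound 1 to compound 3 (0.45 log units; beyond the scatter) both replace the same parent group and both lower the number, the first one by a large margin. The step of a 4.5-fold higher number from compound 2 to compound 3 (0.65 log units; beyond the scatter) runs the other way and raises the number by a modest amount. Compound 4 carries the same trifluoromethyl group as compound 1 together with the chloro group found in compound 2 and compound 3, and both of those chloro-bearing compounds give lower numbers than compound 1 does.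

On this basis compound 4 is expected to give a number close to or somewhat below that of compound 3, a step of a 1.6-fold lower number from compound 3 to compound 4 (0.21 log units; within the scatter) that may stay within the usual scatter. The estimate for compound 4 in this assay is 30 nM, between 10 nM and 90 nM.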

Compound 4, half-maximal inhibitory concentration: 27 nM
Beside the measured number, compound 4's estimate is 1.1-fold (0.05 log units) above it; measured number inside the range.
By their numbers in this assay, from the lowest: compound 2; then compounds 4 and 3 (each within the scatter of the next); then compound 1.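

In this assay, the place para to a large group now holds trifluoromethyl and cyano on the same chloro-bearing ring, and the step of a 1.8-fold lower number from compound 3 to compound 4 (0.26 log units; within the scatter) shows that this assay does not separate the two groups there. For the compounds shown here, compound 4 also gives the first reading of the chloro group on its own: the earlier steps from compound 1 changed two places at once, whereas the step of a 5.1-fold lower number from compound 1 to compound 4 (0.71 log units; beyond the scatter) is a single exchange of chloro for hydrogen with trifluoromethyl held in place, and it accounts for a clear part of the larger step of a 13-fold lower number from compound 1 to compound 2 (1.10 log units; beyond the scatter) to the dichloro compound. Chloro at the place para to a large group keeps the lowest number of the set, as the step of a 2.5-fold higher number from compound 2 to compound 4 (0.39 log units; beyond the scatter) shows for trifluoromethyl and the step of a 4.5-fold higher number from compound 2 to compound 3 (0.65 log units; beyond the scatter) shows for cyano.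

From the compounds shown here alone, how a methoxy group or an amine would read at that same place remains open, as does whether the exchange of hydrogen for chloro would give a step of similar size with cyano or chloro in the other place. No measurement shown here offers an explanation for any of these differences.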